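This account rests on a few compounds, and the source may have more. Where it says the series, first, only, none or still open, it means among the compounds named here.

Three stilbene-like compounds, all carrying fluorine on both rings, have been tested in an assay on HepG2 cells for activation of nuclear factor erythroid 2-related factor 2 (Homo sapiens), read by a luciferase reporter, with a stated time of 5 h; a lower number here means that less compound is needed, a higher number that more compound is needed for the effect. Compound 1 `Fc1ccc(/C=C/c2ccccc2F)cc1F` gives only a limit of the assay, > 15000 nM. Compound 2 `Fc1ccccc1/C=C/c1ccccc1F` gives 4300 nM. Compound 3 `Fc1ccc(/C=C/c2ccccc2F)cc1` gives 3600 nM; the values of compound 2 and compound 3 lie within the scatter of each other, so no order between them is claimed.

Compound 3 and compound 1 differ in one place: fluoro in place of hydrogen on an aromatic carbon. This change gave an at least 4.1-fold higher number from compound 3 to compound 1 (0.61 log units; beyond the scatter), and the end point is the limit noted in the limit of > 15000 nM in this assay, at which 1 of the 3 values shown sits, so the true size of the step is not known beyond that lower bound.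

The unmeasured compound 4 `Fc1ccc(F)c(/C=C/c2ccccc2F)c1` stands to compound 2 as compound 1 stands to compound 3. The change is fluoro in place of hydrogen on an aromatic carbon. The surroundings of the place are not the same: in compound 1 the entering fluoro sits ortho to a fluoro group and meta to a group of 9 heavy atoms, while in compound 4 it sits meta to a group of 9 heavy atoms and para to a fluoro group. It is therefore the same kind of change, not the same change. How the cores of compound 2 and compound 3 differ is not broken down here.

Resting on the single measured step, from compound 3 to compound 1, the expectation for compound 4 is a step of about a 3.5-fold higher number from compound 2 to compound 4 (0.54 log units; beyond the scatter) from compound 2, with the chance that the assay again reports only a limit. Compound 4 is accordingly estimated at 15000 nM, with a range from 6000 nM to 40000 nM.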

Compound 4, half-maximal effective concentration: 5900 nM
Estimate against measurement, compound 4: 2.5-fold (0.41 log units) above; the measured number lies below the stated range.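

Fluoro in place of hydrogen on a second core, tested in this assay, gave a 1.4-fold higher number from compound 2 to compound 4 (0.14 log units; within the scatter), so here the change leaves no step that stands clear of the usual scatter, and the two cores do not respond alike: the same change on two cores in this assay, an at least 4.1-fold higher number (0.61 log units; beyond the scatter) from compound 3 to compound 1 and a 1.4-fold higher number (0.14 log units; within the scatter) from compound 2 to compound 4, at least 3.0-fold (0.48 log units) apart, beyond the scatter of two such steps

Compound 1 gives only a limit of the assay, > 15000 nM, so the first step has a known lower bound but no known size, which means the true gap between the two steps may be larger still: the limit of > 15000 nM in this assay, at which 1 of the 4 values shown sits.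

The pairs show that, in this small set, the step measured on one core was a poor guide to the step on the other, but they do not show what sets the two apart, as the entering fluoro has different surroundings in each pair and that cannot be separated from the difference between the cores.

Every substituent on the rings of the compounds shown is a fluoro group, so it remains open how a methoxy group, an amine or a carboxylic acid at the same place would read in this assay. On these data alone, it also remains open whether a third core would follow compound 1 or compound 4 in its response to the same change.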